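The source may report more compounds than this note shows. Statements on the series, on what has been measured and on what is new or still open speak of the compounds shown alone.

Compounds measured so far:
Compound 1 `Cc1c(F)c(Oc2cccc(C(=N)N)c2)nc(Oc2cccc([N+](=O)[O-])c2)c1F` — in an assay on isolated protein for inhibition of serine protease 1 (Bos taurus) (a higher number here means a weaker inhibitor, a lower number a stronger inhibitor), compound 1 reaches only the limit of the assay, > 5000 nM.
Compound 2 `Cc1c(F)c(Oc2cccc(NS(C)(=O)=O)c2)nc(Oc2cccc(C(=N)N)c2)c1F` — compound 2 gives 1900 nM.
Compound 3 `Cc1c(F)c(Oc2cccc(C(=N)N)c2)nc(Oc2cccc(-n3ccnc3)c2)c1F` — compound 3 gives 4800 nM.

Compound 1 thus stands at the edge of what this assay reports, as a limit and not a number (the limit of > 5000 nM in this assay, at which 1 of the 3 values shown sits). Compound 4 `Cc1c(F)c(Oc2cccc(OC(C)C)c2)nc(Oc2cccc(C(=N)N)c2)c1F` differs from it by isopropoxy in place of nitro on an aromatic carbon. Two measured steps start from the same nitro: an at least 2.6-fold lower number from compound 1 to compound 2 (0.42 log units; beyond the scatter), and an at least 1.0-fold lower number from compound 1 to compound 3 (0.01 log units; that floor lies within the scatter). The replacements at this position therefore ranged from no resolvable change to a modest gain. For compound 4 a modest gain is expected, an at least 1.6-fold lower number from compound 1 to compound 4 (0.22 log units; that floor lies within the scatter). Compound 4 is accordingly estimated at 3000 nM, with a range from 1000 nM to 9000 nM.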

Compound 4, inhibition constant: 2900 nM
For compound 4 the middle estimate is 1.0-fold (0.01 log units) above the measured one, within the range that was stated.
By their numbers in this assay, from the lowest: compounds 2, 4 and 3 (each within the scatter of the next, the first and the last beyond it). At a limit, above all of these: compound 1.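

In this assay, isopropoxy cannot be told apart from either of the two other replacements at this position: a 1.5-fold higher number from compound 2 to compound 4 (0.18 log units; within the scatter), and a 1.7-fold lower number from compound 3 to compound 4 (0.22 log units; within the scatter). Compound 4 thus lies within the scatter of two compounds that are themselves separated by a 2.5-fold higher number from compound 2 to compound 3 (0.40 log units; beyond the scatter). The step from nitro gives only a floor, an at least 1.7-fold lower number from compound 1 to compound 4 (0.23 log units; that floor lies within the scatter), and compound 1 remains a limit and not a number: the limit of > 5000 nM in this assay, at which 1 of the 4 values shown sits.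

It remains open whether an amine or a carboxylic acid at this position would give a number outside the scatter of these compounds. On these data alone, it is equally open whether an alkoxy group with a longer chain would do so.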